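Sulfonamide series against mitochondrial malate dehydrogenase: outlook for compound 4

The source may hold more compounds than are shown below. What is called first, only, known or untested is meant among the compounds shown, and "the series" means these compounds.

Measured so far:
compound 1 `O=S(=O)(Nc1ccc2oc(-c3ccccc3)nc2c1)c1ccccc1O`: > 63000 nM
compound 2 `O=S(=O)(Nc1ccc2oc(-c3ccccc3)nc2c1)c1ccc(Cl)c(Cl)c1`: > 63000 nM
compound 3 `COc1ccc(S(=O)(=O)Nc2ccc(-c3nc4ccccc4o3)cc2)cc1`: > 63000 nM

In an assay on isolated protein for inhibition of malate dehydrogenase, mitochondrial (Sus scrofa), with stated times of 45 min and 30 min (on this read-out lower numbers stand for stronger inhibition and higher numbers for weaker inhibition), compound 1 gives > 63000 nM, which is a limit of the assay and not a number. Compound 2 gives > 63000 nM in this assay, again a limit. The step that the two limits leave unreadable from compound 1 to compound 2 is therefore unreadable. Compound 3 gives > 63000 nM in this assay, also a limit. Compound 3 thus stands where every value in the series stands, at the limit of > 63000 nM in this assay, at which 3 of the 3 values shown sit; no number separates it from compound 1 or compound 2.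

Compound 4 `COc1ccc(Cl)cc1S(=O)(=O)Nc1ccc(-c2nc3ccccc3o2)cc1` differs from compound 3 in one place: 5-chloro-2-methoxyphenyl in place of 4-methoxyphenyl on a sulfonyl sulfur. For the measured compounds named here, the only measured step, the one from compound 1 to compound 2, also changes the aryl group on the sulfonyl sulfur, yet its size is not readable, so it gives no direction for this assay. Compound 4 is expected at 80000 nM, in the range 20000 nM to 300000 nM, most probably again reported as a limit. The expected step that the limit leaves unreadable from compound 3 to compound 4 is one of no change beyond the scatter.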

Compound 4, half-maximal inhibitory concentration: > 63000 nM
Compound 4: no number, only a limit; the forecaster's own chance of this, stated with the estimate: 80%; the middle value lies beyond the limit too.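

In this assay the step from compound 3 to compound 4 cannot be read, since neither compound has a number: the limit of > 63000 nM in this assay, at which 4 of the 4 values shown sit.

The compounds shown leave open whether any aryl group on a sulfonyl sulfur changes inhibition in this assay at all, and how far each compound lies from that limit.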